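Replacing the para-tolyl of compound 1 with a 2-chlorophenyl

A few compounds are considered here, and "the series" means these few. Any claim that something is new, unique, unknown or untested is made for them only; others in the source may bear on it.

Three compounds built on the same core were assessed in an ADME assay on MRC5 cells (Homo sapiens) for cytotoxicity, read by MTT assay, with a stated time of 24 h; a lower number here means a stronger inhibitor, a higher number a weaker inhibitor. Compound 1 `CCOC(=O)c1c(C)[nH]c(=O)c(C#N)c1-c1ccc(C)cc1` gives 438000 nM there, the lowest of the three numbers. Compound 2 `CCOC(=O)c1c(C)[nH]c(=O)c(C#N)c1-c1ccc([N+](=O)[O-])cc1` gives 2230000 nM and compound 3 `CCOC(=O)c1c(C)[nH]c(=O)c(C#N)c1-c1ccc(C#N)cc1` gives 1220000 nM. Both steps away from compound 1 went upward: a 5.1-fold higher number from compound 1 to compound 2 (0.71 log units; beyond the scatter) and a 2.8-fold higher number from compound 1 to compound 3 (0.44 log units; beyond the scatter), while the step of a 1.8-fold lower number from compound 2 to compound 3 (0.26 log units; within the scatter) separates compound 2 from compound 3.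

The untested compound 4 `CCOC(=O)c1c(C)[nH]c(=O)c(C#N)c1-c1ccccc1Cl` differs from compound 1 at the same aromatic carbon: 2-chlorophenyl in place of 4-methylphenyl on an aromatic carbon. Within the data shown here, no measured step places a 2-chlorophenyl at that position, so the only guidance is that the two changes made so far at the methyl of compound 1, to nitro and to cyano, each produced a higher number. A 2-chlorophenyl is a different change from either of those, and its effect cannot be read directly from them.

Compound 4 is therefore expected to land somewhat higher than compound 1, with a 1.7-fold higher number from compound 1 to compound 4 (0.23 log units; within the scatter) as the estimated step, though a result within the scatter of compound 1 would not be surprising. The estimate for compound 4 is 750000 nM, with a range from 300000 nM to 2000000 nM.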

Compound 4, half-maximal inhibitory concentration: 229000 nM
For compound 4 the middle estimate is 3.3-fold (0.52 log units) above the measured one, and the stated range ends above it.
By their numbers in this assay, from the lowest: compounds 4 and 1 (each within the scatter of the next); then compounds 3 and 2 (each within the scatter of the next).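

In this assay, among these compounds, the 2-chlorophenyl in place of 4-methylphenyl gave a 1.9-fold lower number from compound 1 to compound 4 (0.28 log units; within the scatter) and so is the first change at this aromatic carbon that cannot be told apart from compound 1. The two earlier changes both moved the number beyond the scatter, with a 5.1-fold higher number from compound 1 to compound 2 (0.71 log units; beyond the scatter) and a 2.8-fold higher number from compound 1 to compound 3 (0.44 log units; beyond the scatter) as their steps, so compound 4 goes against any reading that every change here gives a higher number. This step alters both the identity of the substituent and where it stands on the phenyl ring, and nothing on hand separates those two parts or explains the outcome.

The compounds shown leave open whether a 4-chlorophenyl would group with compound 1 or with compound 2 and compound 3, and whether a 2-methylphenyl would read like compound 4, which would help separate the chlorine from its place on the ring. Also open, from the compounds shown here alone, is how an amine or a carboxylic acid on that phenyl ring would read in this assay and whether a longer chain in place of the ethoxycarbonyl group would move the number at all.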